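Working notes: methylating a hydroxy group on compound 1

The source may hold more compounds than are shown below. What is called first, only, known or untested is meant among the compounds shown, and "the series" means these compounds.

Measured in a functional assay on K562 cells (Homo sapiens) for cytotoxicity, read by sulforhodamine B assay, with a stated time of 48 h (a lower number here means a stronger inhibitor of growth, a higher number a weaker inhibitor of growth), so far:
- compound 1 `COc1cc(C(=O)c2ccc(OC)c(O)c2OC)cc(OC)c1O` gives 153 nM
- compound 2 `COc1cc(C(=O)c2ccc3c(c2)oc(=O)n3S(C)(=O)=O)cc(OC)c1OC` gives 588 nM

Of these two, compound 1 holds the lower number, and the gap to compound 2 lies beyond the scatter. Compound 3 `COc1ccc(C(=O)c2cc(OC)c(OC)c(OC)c2)c(OC)c1O` carries methyl in place of hydrogen on an oxygen on an aromatic ring, hydroxy to methoxy, relative to compound 1 methyl in place of hydrogen on an oxygen on an aromatic ring in one place. Within the data shown here, no measured pair shows this change, so the expectation in this assay is loose: a move to a lower number, beyond the scatter. An estimated 3.8-fold lower number from compound 1 to compound 3 (0.58 log units; beyond the scatter) is expected on that basis. For compound 3 the expected value is 40 nM with an estimated range from 10 nM to 150 nM around it.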

Compound 3, concentration for 50% growth inhibition: < 10 nM
Compound 3: only a limit was reported; the forecaster's own chance of this, stated with the estimate: 3%; at least 4.0-fold (0.60 log units) between middle value and limit.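

Hydroxy to methoxy on this oxygen gives an at least 15-fold lower number from compound 1 to compound 3 (1.18 log units; beyond the scatter), so in this assay a free hydroxy group here is not needed for growth inhibition, and capping it with methyl brings a large step. For compound 3 the value of < 10 nM is a limit and not a number, so the step gives only a minimum size: the limit of < 10 nM in this assay, at which 1 of the 3 values shown sits.

Still open, on these data alone, is how far compound 3 lies past that limit. The compounds shown also leave open whether an ethyl group or a longer chain on this oxygen, or an amine in its place, would hold this level.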